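Hydroxyphenyl position change on the piperazinyl core

The source may hold more compounds than are shown below. What is called first, only, known or untested is meant among the compounds shown, and "the series" means these compounds.

Working notes on the series in an assay on cells for displacement of a labelled ligand from adenosine receptor A1 (Homo sapiens), read by scintillation counting and radioligand binding, with a stated time of 60 min, tested at 10 uM; a higher number here means more inhibition at the concentration tested (going by the name of the read-out), a lower number less inhibition. Among the compounds with values here, compound 1 `CN1CCN(c2nc(-c3cccc(O)c3)nc3c2ncn3C)CC1` gives 27.1%, the only plain number among the three values recorded here. Compound 2 `CN1CCN(c2nc(-c3cc(Cl)ccc3Cl)nc3[nH]cnc23)CC1` is reported only as a limit, > 80%, not as a number. Compound 3 `Oc1cccc(-c2nc(N3CCCCC3)c3nc[nH]c3n2)c1` is likewise reported only as a limit, > 80%. Within the data shown here, two of the three values thus rest at the limit of > 80% in this assay, at which 2 of the 3 values shown sit, so no measured step between neighbouring compounds can be drawn, and compound 1 stands on its own as the single quantified point.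

Compound 4 `CN1CCN(c2nc(-c3ccccc3O)nc3c2ncn3C)CC1` differs from compound 1 by 2-hydroxyphenyl in place of 3-hydroxyphenyl on an aromatic carbon. Among the measured compounds shown here, no step of this kind has been measured in this assay, so the size of the change is open. The step of a number 5.9 percentage points higher from compound 1 to compound 4 (within the scatter) is expected to be modest, likely within or only just beyond the usual scatter, in either direction. Compound 4 is accordingly expected to show about 33%, with a range from 10% to 65%.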

Compound 4, a percentage reported as inhibition, at one concentration (the size of the read-out at that concentration, not a potency): > 80%
Compound 4 was reported as a limit (the forecaster's own chance of this, stated with the estimate: 12%); at least 47 percentage points between middle value and limit.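

In this assay, 2-hydroxyphenyl in place of 3-hydroxyphenyl on the shared core gives a number at least 52.9 percentage points higher from compound 1 to compound 4 (beyond the scatter). Within the data shown here, this is the first step measured, and it shows that the read-out at this aromatic carbon depends strongly on where the hydroxyl sits on the phenyl group, even though the two groups have the same atoms. The full size of the step cannot be read, since compound 4 is reported only as a limit, as most of the series now is: the limit of > 80% in this assay, at which 3 of the 4 values shown sit.

Going by these compounds, whether 4-hydroxyphenyl, a methoxyphenyl or an aminophenyl group at this carbon would stay at the limit or fall to a plain number remains open. Compound 4 also cannot be ranked against compound 2 or compound 3, whose values are limits as well and which differ from it in more than one place.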